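This account rests on a few compounds, and the source may have more. Where it says the series, first, only, none or still open, it means among the compounds named here.

Measured in a functional assay on ECa-109 cells for inhibition, with ECa-109 cell line (Homo sapiens) as the target, read by sulforhodamine B assay; a higher number here means a weaker inhibitor, a lower number a stronger inhibitor:
- compound 1 `O=C1C(Nc2ccc(Br)cc2)=CC(=O)c2c1nc1n2[C@H]2OC[C@@H](O)[C@H]2OC1`: 1980 nM
- compound 2 `COc1ccccc1NC1=CC(=O)c2c(nc3n2[C@H]2OC[C@@H](O)[C@H]2OC3)C1=O`: > 4000 nM (a limit)
- compound 3 `O=C1C(Nc2ccc(C(F)(F)F)cc2)=CC(=O)c2c1nc1n2[C@H]2OC[C@@H](O)[C@H]2OC1`: not yet measured

Compound 2 stands at > 4000 nM, which is a limit of the assay and not a number. Its exact place in the series is therefore unknown.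

The next change is 4-(trifluoromethyl)phenyl in place of 2-methoxyphenyl on an amine nitrogen.

Among the measured compounds shown here, one measured step bears on this change: an at least 2.0-fold higher number from compound 1 to compound 2 (0.30 log units; that floor lies within the scatter). It replaces 4-bromophenyl with 2-methoxyphenyl on the same amine nitrogen, and it gives only a floor for the size of the change. The closest measured analogue of compound 3 is compound 1, which carries 4-bromophenyl and gives 1980 nM. On that basis, a move towards a lower number in this assay is expected, although its size is poorly defined and a result within the scatter remains possible. The expected change is an at least 1.6-fold lower number from compound 2 to compound 3 (0.20 log units; that floor lies within the scatter). Compound 3 is estimated at 2500 nM, with an expected range of 1000 nM to 6000 nM.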

Compound 3, half-maximal inhibitory concentration: 2250 nM
For compound 3 the middle estimate is 1.1-fold (0.05 log units) above the measured one, within the range that was stated.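

In this assay, 4-(trifluoromethyl)phenyl in place of 2-methoxyphenyl on the amine nitrogen gives an at least 1.7-fold lower number from compound 2 to compound 3 (0.24 log units; that floor lies within the scatter). The true size of that step cannot be read because the value of compound 2 is a limit and not a number: the limit of > 4000 nM in this assay, at which 1 of the 3 values shown sits. Trifluoromethyl in place of bromo on an aromatic carbon gives a 1.1-fold higher number from compound 1 to compound 3 (0.06 log units; within the scatter), so the two compounds with a single group at the 4-position of the phenyl ring cannot be told apart in this assay, and the second such group shows that the value of compound 1 is not unique to bromo.

Open, from the compounds shown here alone, is how a 4-methoxyphenyl group would stand on the same amine nitrogen, which would show whether the limit of compound 2 goes with the methoxy group itself or with its place on the ring. Also open, going by these compounds, is how far the series tolerates other groups at this nitrogen, such as an unsubstituted phenyl, a 4-aminophenyl or a cyclohexyl group in place of the aromatic ring.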